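The source may report more compounds than this note shows. Statements on the series, on what has been measured and on what is new or still open speak of the compounds shown alone.

Measured in a functional assay on HeLa cells (Homo sapiens) for antiproliferative activity, read by cell counting, with a stated time of 2 days; on this read-out higher numbers stand for weaker inhibition and lower numbers for stronger inhibition:
- compound 1 `COc1ccc(C(=O)c2sc(N3CCCC3)nc2N)cc1`: > 200000 nM, a limit of the assay
- compound 2 `COc1ccccc1C(=O)c1sc(N2CCCC2)nc1N`: 185000 nM
- compound 3 `Nc1nc(N2CCCC2)sc1C(=O)c1ccc(Cl)cc1`: > 200000 nM, a limit of the assay

Compound 3 stands only at a limit, > 200000 nM. Compound 1 gives the same limit, so the series mostly sits at the limit of > 200000 nM in this assay, at which 2 of the 3 values shown sit. Compound 2 is the only one of the three that reads as a number.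

Compound 4 `Nc1nc(N2CCCC2)sc1C(=O)c1ccccc1` follows from compound 3 through hydrogen in place of chloro on an aromatic carbon, para to a large group. Among the measured compounds shown here, the one measured step that bears on this change is a step that the two limits leave unreadable from compound 1 to compound 3, chloro in place of methoxy on an aromatic carbon. It gives no size to carry over. No step beyond the scatter is therefore expected in this assay, in either direction, and another limit is a likely outcome. The expectation of a number in this region rests on compound 2 at 185000 nM. The expected change is an at least 1.0-fold lower number from compound 3 to compound 4 (0.02 log units; that floor lies within the scatter), an estimate that stays within the scatter. Compound 4 is estimated at 190000 nM, with an expected range of 90000 nM to 400000 nM.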

Compound 4, half-maximal inhibitory concentration: > 200000 nM
Compound 4 was reported as a limit (the forecaster's own chance of this, stated with the estimate: 65%); middle value at least 1.0-fold (0.02 log units) from the limit.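

In this assay compound 4, with hydrogen on the aromatic carbon para to a large group, is again a limit of the assay, so taking away the chloro brings no reading into measurable range. Both ends of the steps from compound 3 and from compound 1 to compound 4 are limits, and neither step can be read. The one step with a size is an at least 1.0-fold higher number from compound 2 to compound 4 (0.03 log units; that floor lies within the scatter); it is a floor and not a measured gap, and the series now sits mostly at one ceiling: the limit of > 200000 nM in this assay, at which 3 of the 4 values shown sit.

Among the compounds shown here, still open is whether any group on this aromatic ring gives a reading clearly stronger than that of compound 2, which at 185000 nM is the only number so far. Also open, going by these compounds, is what a carboxylic acid or a dimethylamino group on that aromatic carbon would read, or a longer chain elsewhere on the shared core.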